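Series notes: swapping the group on the carbonyl carbon

The source may report more compounds than this note shows. Statements on the series, on what has been measured and on what is new or still open speak of the compounds shown alone.

Of the compounds shown here, two sharing one core have numbers so far in a functional assay on HepG2 cells (Homo sapiens), read by MTT assay, with a stated time of 48 h; a higher number here means a weaker inhibitor, a lower number a stronger inhibitor. Compound 1 `CCn1c(C(=O)N(CCC#N)CCC#N)ccc1C(CC)(CC)c1ccc(OCC(O)C(C)(C)C)c(C)c1` gives 42000 nM. Compound 2 `CCn1c(C(=O)N(C)CC(=O)O)ccc1C(CC)(CC)c1ccc(OCC(O)C(C)(C)C)c(C)c1` gives 17100 nM, the lower of the two numbers, which makes it the stronger inhibitor of this pair.

The next compound is compound 3 `CCn1c(C(=O)OCc2ccc(F)cc2)ccc1C(CC)(CC)c1ccc(OCC(O)C(C)(C)C)c(C)c1`, with (4-fluorobenzyl)oxy in place of (carboxymethyl)(methyl)amino on a carbonyl carbon.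

For the measured compounds named here, only one measured step bears on this change: a 2.5-fold lower number from compound 1 to compound 2 (0.39 log units; beyond the scatter), a modest step that also alters the group on the carbonyl carbon. Neither measured compound carries (4-fluorobenzyl)oxy, so that step gives a rough size for changes at this place but no direction. With no evidence for a direction, no shift beyond the scatter is expected, though a modest move either way would not surprise. The expected step is a 1.2-fold higher number from compound 2 to compound 3 (0.07 log units; within the scatter). For compound 3 the estimated value is 20000 nM, with an expected range from 6000 nM to 60000 nM.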

Compound 3, half-maximal inhibitory concentration: > 50000 nM
Compound 3: only a limit was reported; the forecaster's own chance of this, stated with the estimate: 15%; middle value at least 2.5-fold (0.39 log units) away from the limit.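

In this assay, (4-fluorobenzyl)oxy in place of (carboxymethyl)(methyl)amino on the carbonyl carbon gives an at least 2.9-fold higher number from compound 2 to compound 3 (0.46 log units; beyond the scatter), so this swap raises the number and the aromatic ring-bearing group does not match the lower number set by the group it replaces. The other comparison gives an at least 1.1-fold higher number from compound 1 to compound 3 (0.07 log units; that floor lies within the scatter), and that floor does not set the two groups apart, so of the two earlier groups only (carboxymethyl)(methyl)amino is clearly separated from the new one. The reading for compound 3 is a limit of the assay and not a number, so the true size of both steps stays unknown, and it is the only such reading in the set: the limit of > 50000 nM in this assay, at which 1 of the 3 values shown sits.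

Compound 2 holds the lowest number of the three, but the step to compound 3 changes the carboxylic acid, the linking nitrogen and the aromatic ring together, and these cannot be told apart here. Still open, going by these compounds, is whether a benzylamino group, which would keep the linking nitrogen with an aromatic ring, or a carboxylic acid on a longer chain would move the number further in either direction.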